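This account rests on a few compounds, and the source may have more. Where it says the series, first, only, none or still open, it means among the compounds named here.

Measured so far in an assay for binding affinity to histamine H2 receptor (Homo sapiens); a higher number here means a weaker inhibitor, a lower number a stronger inhibitor:
compound 1 `C[C@@H](NC(=O)OC(C)(C)C)C(=O)N1CCN(CCCOc2ccc(C(=O)C3CC3)cc2)CC1` gives 83200 nM
compound 2 `N[C@H](CC1CCCCC1)C(=O)N1CCN(CCCOc2ccc(C(=O)C3CC3)cc2)CC1` gives 20400 nM

Among the compounds with values here, compound 2 holds the lowest of the two numbers; compound 1 sits a 4.1-fold lower number from compound 1 to compound 2 (0.61 log units; beyond the scatter) away, the only step measured. Compound 3 `CCC[C@@H](N)C(=O)N1CCN(CCCOc2ccc(C(=O)C3CC3)cc2)CC1` differs from compound 2 by ethyl in place of cyclohexyl on a saturated chain carbon, two bonds along the chain from an amine nitrogen and a carbonyl carbon. Within the data shown here, no measured step trims the same position, so the one step from compound 1 to compound 2 bears only loosely, showing that changes to this side chain shift this assay by a modest amount. A modest rise in the number is therefore expected, as a 2.0-fold higher number from compound 2 to compound 3 (0.29 log units; within the scatter). Compound 3 is estimated at 40000 nM in this assay, within 10000 nM to 150000 nM.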

Compound 3, inhibition constant: 60300 nM
For compound 3 the middle estimate is 1.5-fold (0.18 log units) below the measured one; the measured number falls inside the stated range.
By their numbers in this assay, from the lowest: compound 2; then compounds 3 and 1 (each within the scatter of the next).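

In this assay, within the data shown here, ethyl in place of cyclohexyl gives a 3.0-fold higher number from compound 2 to compound 3 (0.47 log units; beyond the scatter), the only measured change confined to this side chain, and it leaves compound 2 with the lowest number of the three. 1-Aminobutyl in place of 1-((tert-butoxycarbonyl)amino)ethyl gives a 1.4-fold lower number from compound 1 to compound 3 (0.14 log units; within the scatter), so this exchange does not separate compound 3 from compound 1. No available evidence accounts for the size of either step. Open, from the compounds shown here alone, is whether phenyl or a longer saturated chain on this carbon would give a number closer to that of cyclohexyl, or lower still.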